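This account rests on a few compounds, and the source may have more. Where it says the series, first, only, none or still open, it means among the compounds named here.

Working notes on the series in a functional assay on CHO-K1 cells for agonist activity at Orexin/Hypocretin receptor type 1 (Homo sapiens), read by FLIPR and calcium flux; on this read-out higher numbers stand for an effect only at larger amounts of compound and lower numbers for an effect already at smaller amounts. Among the compounds with values here, compound 1 `CC(=O)N1CCC[C@H](NS(C)(=O)=O)[C@@H]1CO[C@H]1CC[C@@H](C(C)C)CC1` is one of the two measured members. In this assay compound 1 returns only a limit, > 100000 nM. Compound 2 `CCC(=O)N1CCC[C@H](NS(C)(=O)=O)[C@@H]1CO[C@H]1CC[C@@H](c2ccccc2)CC1` is the other measured member and the starting point for the next step. In this assay compound 2 likewise returns only a limit, > 100000 nM. Within the data shown here, both measured values thus sit at the same limit (the limit of > 100000 nM in this assay, at which 2 of the 2 values shown sit), so no step between measured compounds can be sized, and where compound 2 stands can be said only as: at the limit, together with compound 1.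

Compound 3 `CCNC(=O)N1CCC[C@H](NS(C)(=O)=O)[C@@H]1CO[C@H]1CC[C@@H](c2ccccc2)CC1` differs from compound 2 by ethylamino in place of ethyl on a carbonyl carbon, read one bond further out as propanoyl to ethylcarbamoyl. The measured compounds give no direction for this change, as neither yields a number. The step from compound 2 to compound 3 is expected to be a step that the limit leaves unreadable from compound 2 to compound 3, none beyond the scatter, with the result most likely again a limit. Compound 3 is estimated at 150000 nM, expected within 30000 nM to 1000000 nM.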

Compound 3, half-maximal effective concentration: > 14000 nM
Compound 3: no number, only a limit; the forecaster's own chance of this, stated with the estimate: 85%; the middle value is on the limit's open side.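

In this assay compound 3 gives > 14000 nM, which is a limit and not a number. Within the data shown here, compound 2 likewise returns only a limit, so no step from compound 2 to compound 3 can be read. The compounds shown leave open whether ethylamino in place of ethyl on a carbonyl carbon changes the response in this assay at all.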